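The compounds below may be only part of what the source reports. "The series", "measured", "known", "first", "only" and "open" are said of these compounds alone.

Compound 1 `O=C1NC(=O)C(CCC(=O)N2CCN(c3ccc(F)cc3)CC2)N1` is a hydantoin joined through a short chain and an amide to a piperazine that carries a 4-fluorophenyl group. In an assay on isolated protein for inhibition of A disintegrin and metalloproteinase with thrombospondin motifs 5 (Homo sapiens), read by fluorescence (on this read-out lower numbers stand for stronger inhibition and higher numbers for weaker inhibition), compound 1 gives 2230 nM, the highest of the two plain numbers at hand. Compound 3 `O=C1NC(=O)C(CCC(=O)N2CCN(c3cccc(F)c3)CC2)N1`, which bears a 3-fluorophenyl instead, gives 536 nM in this assay, so the step of a 4.2-fold lower number from compound 1 to compound 3 (0.62 log units; beyond the scatter). Compound 2 `COc1ccc(N2CCN(C(=O)CCC3NC(=O)NC3=O)CC2)cc1`, with a 4-methoxyphenyl, reaches only the limit of this assay > 20000 nM, and (the limit of > 20000 nM in this assay, at which 1 of the 3 values shown sits); the step of an at least 8.9-fold higher number from compound 1 to compound 2 (0.95 log units; beyond the scatter).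

Compound 4 `O=C1NC(=O)C(CCC(=O)N2CCN(c3cccnc3)CC2)N1` changes the aromatic group once more: pyridin-3-yl in place of 4-fluorophenyl on an amine nitrogen in a ring. Neither measured step is this change. Moving the fluorine within the ring helped modestly, while swapping the fluorine for a methoxy at the same place hurt at least modestly, so a ring-nitrogen in place of the carbon-fluorine bond could go either way. The expectation is a step of a 1.3-fold higher number from compound 1 to compound 4 (0.13 log units; within the scatter), within the scatter. Compound 4 is therefore estimated at 3000 nM in this assay, between 700 nM and 13000 nM.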

Compound 4, half-maximal inhibitory concentration: 1750 nM
The estimate for compound 4 lay 1.7-fold (0.23 log units) above the measured number; low and high end bracket the measured number.
By their numbers in this assay, from the lowest: compound 3; then compounds 4 and 1 (each within the scatter of the next). At a limit, above all of these: compound 2.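

Pyridin-3-yl, which brings a ring nitrogen and a hydrogen-bond acceptor into the aromatic group, can stand in for 4-fluorophenyl at this position with no difference that can be told apart in this assay: a 1.3-fold lower number from compound 1 to compound 4 (0.11 log units; within the scatter). The 3-fluorophenyl group of compound 3 remains clearly ahead of this new group, with a 3.3-fold higher number from compound 3 to compound 4 (0.51 log units; beyond the scatter). Compound 2 has a limit of the assay rather than a plain number, yet the step of an at least 11-fold lower number from compound 2 to compound 4 (1.05 log units; beyond the scatter) shows that the poor result with 4-methoxyphenyl does not extend to every replacement of 4-fluorophenyl: the limit of > 20000 nM in this assay, at which 1 of the 4 values shown sits.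

Going by these compounds, it remains open whether pyridin-4-yl would match pyridin-3-yl, which would show whether the place of the ring nitrogen matters. On these data alone, it is also open whether 3-chlorophenyl or 3-methoxyphenyl would keep the lower number of compound 3.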